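Swapping the Aryl Sulfone in a Quinoline Series

The compounds below may be only part of what the source reports. "The series", "measured", "known", "first", "only" and "open" are said of these compounds alone.

Three compounds share a core and differ only in the aryl group on the sulfonyl sulfur or in the core itself. In an assay on isolated protein for displacement of a labelled ligand from metabotropic glutamate receptor 5 (Homo sapiens), with a stated time of 60 min, tested at 1 uM (on this read-out lower numbers stand for less inhibition and higher numbers for more inhibition at the one concentration tested (going by the name of the read-out)), compound 3 `Cc1ccc2ncc(S(=O)(=O)c3ccc(C)c(Cl)c3)c(N3CCC(C)CC3)c2c1` gives 91%, the highest of the three numbers; compound 1 `COc1cccc(S(=O)(=O)c2cnc3ccc(Cl)cc3c2N2CCC(C)CC2)c1` gives 87%, within the scatter of compound 3, while compound 2 `Cc1ccc2ncc(S(=O)(=O)c3cccc(C#N)c3)c(N3CCC(C)CC3)c2c1` gives 52%, well below it.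

Compound 4 `COc1cccc(S(=O)(=O)c2cnc3ccc(C)cc3c2N2CCC(C)CC2)c1` is not yet measured. Relative to compound 3 it carries 3-methoxyphenyl in place of 3-chloro-4-methylphenyl on a sulfonyl sulfur.

Among the measured compounds shown here, only one measured step touches the group on the sulfonyl sulfur: a number 39 percentage points higher from compound 2 to compound 3 (beyond the scatter). That step shows the position matters, but it does not involve 3-methoxyphenyl. Compound 1 does carry 3-methoxyphenyl on its sulfonyl sulfur, on a different core, and there it gives 87%, close to compound 3.

Compound 4 is therefore expected to stay near compound 3, with a step of about a number 6 percentage points lower from compound 3 to compound 4 (within the scatter) in this assay, inside the scatter. The estimate for compound 4 is 85%, in a range from 70% to 95%.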

Compound 4, a percentage reported as inhibition, at one concentration (the size of the read-out at that concentration, not a potency): 96%
Beside the measured number, compound 4's estimate is 11 percentage points below it, outside the stated range (above it).
By their numbers in this assay, from the lowest: compound 2; then compounds 1, 3 and 4 (each within the scatter of the next).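

On the shared core, 3-methoxyphenyl on a sulfonyl sulfur serves as well as 3-chloro-4-methylphenyl: in this assay, the swap gives a number 5 percentage points higher from compound 3 to compound 4 (within the scatter), so these two aryl groups are not told apart here. Methoxy in place of cyano on an aromatic carbon gives a number 44 percentage points higher from compound 2 to compound 4 (beyond the scatter), which singles out 3-cyanophenyl as the one aryl group on this core that goes with a clearly lower number. Methyl in place of chloro on an aromatic carbon gives a number 9 percentage points higher from compound 1 to compound 4 (within the scatter), so that change to the core also makes no clear difference.

Nothing available explains why the cyano compound sits lower. Still open, on these data alone, are how an amine or a carboxylic acid on this aryl ring would fare, and whether compounds 1, 3 and 4 would separate at lower concentrations.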